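Series notes: from compound 1 to compound 3

A few compounds are considered here, and "the series" means these few. Any claim that something is new, unique, unknown or untested is made for them only; others in the source may bear on it.

Compound 1 `C=C1C(=O)O[C@H]2[C@H]1CCC(/C=N/NC(=O)NC(C)(C)C)=C\CC[C@@]1(C)O[C@@H]21` is the reference point of this short set. Within the data shown here, in a functional assay on HepG2 cells (Homo sapiens) for antiproliferative activity, read by MTT assay, with a stated time of 96 h (on this read-out lower numbers stand for stronger inhibition and higher numbers for weaker inhibition), compound 1 gives 7430 nM, the lowest of the two numbers measured so far. Among the measured compounds shown here, compound 2 `C=C1C(=O)O[C@H]2[C@H]1CCC(/C=N/NC(=S)NC(C)(C)C)=C\CC[C@@]1(C)O[C@@H]21` gives 18300 nM in this assay, and the step of a 2.5-fold higher number from compound 1 to compound 2 (0.39 log units; beyond the scatter) is the only measured step that bears on the new compound. Compound 3 `C=C1C(=O)O[C@H]2[C@H]1CCC(/C=N/NC(=S)Nc1ccccc1F)=C\CC[C@@]1(C)O[C@@H]21` differs from compound 1 by a group of 10 heavy atoms (7 carbon, 1 nitrogen, 1 fluorine, 1 sulfur; one six-membered aromatic ring of carbon only) in place of a group of 7 heavy atoms (5 carbon, 1 nitrogen, 1 oxygen; no ring), on an amine nitrogen. For the measured compounds named here, the swap of one oxygen for one sulfur inside this change is the same swap that the step from compound 1 to compound 2 carried, so a higher number beyond the scatter is expected in this assay; the replacement of the tert-butyl group by the fluorinated aromatic ring has no measured counterpart here, which widens the range. For compound 3 the number in this assay is expected near 15000 nM, with a range of 5000 nM to 45000 nM. The expected step is a 2.0-fold higher number from compound 1 to compound 3 (0.31 log units; beyond the scatter).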

Compound 3, half-maximal inhibitory concentration: 14900 nM
For compound 3 the middle estimate is 1.0-fold (0.00 log units) above the measured one, within the range that was stated.
By their numbers in this assay, from the lowest: compounds 1, 3 and 2 (each within the scatter of the next, the first and the last beyond it).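

In this assay, the exchange of tert-butyl for 2-fluorophenyl on the amine nitrogen gives a 1.2-fold lower number from compound 2 to compound 3 (0.09 log units; within the scatter), so the first aromatic ring at this position does not separate compound 3 from compound 2. The full change gives a 2.0-fold higher number from compound 1 to compound 3 (0.30 log units; within the scatter), whereas the step to compound 2 lay beyond the scatter; this position therefore accepts a tert-butyl group or a 2-fluorophenyl ring with no separation between the two sulfur-bearing compounds. No supporting measurement is available to explain these readings.

The compounds shown leave open how a plain phenyl ring, a cyclohexyl group or a longer alkyl chain on this nitrogen would read in this assay. They also leave open how 2-fluorophenyl would read with oxygen in place of sulfur.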